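Working notes: phenyl for propyl, compound 2 to compound 4

A few compounds are considered here, and "the series" means these few. Any claim that something is new, unique, unknown or untested is made for them only; others in the source may bear on it.

Measured so far:
compound 1 `CCc1nc(C)c2cnnc(S)n12` — > 48000 nM
compound 2 `CCCc1nnc(SC)n2c(CCC)nc(C)c12` — > 48000 nM
compound 3 `CCCc1nc(Br)c2cnnc(O)n12` — > 48000 nM

In a functional assay for inhibition, with Homo sapiens as the target (a lower number here means a stronger inhibitor, a higher number a weaker inhibitor), compound 1 gives > 48000 nM, which is a limit of the assay and not a number. Compound 2 gives > 48000 nM in this assay, again a limit. Compound 3 gives > 48000 nM in this assay, also a limit. Compound 2 therefore stands where every value in the set stands: the limit of > 48000 nM in this assay, at which 3 of the 3 values shown sit. For the measured compounds named here, no two measured compounds differ in a single place, so no measured step is available to guide the next change.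

Compound 4 `CCCc1nc(C)c2c(-c3ccccc3)nnc(SC)n12` differs from compound 2 in one place: phenyl in place of propyl on an aromatic carbon. With compound 2 at the limit, a weakening could not be seen in this assay, and only a gain beyond the scatter would register as a number. Given that compound 2 gives > 48000 nM, compound 4 is expected to remain near the limit. The estimated step is a step that the limit leaves unreadable from compound 2 to compound 4. For compound 4 the expected value is 50000 nM, with a range from 8000 nM to 200000 nM.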

Compound 4, half-maximal inhibitory concentration: > 48000 nM
Compound 4: no number, only a limit; the forecaster's own chance of this, stated with the estimate: 65%; the middle value is on the limit's open side.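

No step can be read from compound 2 to compound 4, since each gives only a limit of the assay in this assay: the limit of > 48000 nM in this assay, at which 4 of the 4 values shown sit.

The compounds shown leave open whether any change on the shared core yields a number rather than a limit in this assay.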